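Hydroxylated sulfonyl chain on a glucose-dependent insulinotropic receptor agonist

This account rests on a few compounds, and the source may have more. Where it says the series, first, only, none or still open, it means among the compounds named here.

The measured compounds:
compound 1, `CCCc1cnc(N2CCC(C3Cc4c(ccc(C5=CCN(S(=O)(=O)CCC)CC5)c4F)O3)CC2)nc1`: 123%
compound 2, `CCCc1cnc(N2CCC(C3Cc4c(F)c(C5=CCN(S(=O)(=O)CCC)CC5)cc(F)c4O3)CC2)nc1`: 119%

Compound 1 and compound 2 were both tested in a functional assay on HEK293 cells with Glucose-dependent insulinotropic receptor (Homo sapiens) as the target, read by cAMP accumulation, with a stated time of 60 min; on this read-out higher numbers stand for larger maximal responses and lower numbers for smaller maximal responses. Compound 1 reaches 123%, and compound 2 reaches 119%. For the measured compounds named here, the one measured step, a number 4 percentage points lower from compound 1 to compound 2 (within the scatter), lies within the scatter, so compound 2 stands together with compound 1 and the two numbers cannot be told apart.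

Compound 3, `CCCc1cnc(N2CCC(C3Cc4c(F)c(C5=CCN(S(=O)(=O)CCC(C)(C)O)CC5)cc(F)c4O3)CC2)nc1`, has not yet been measured in this assay. Compared with compound 2 the change is 1-hydroxy-1-methylethyl in place of methyl on a saturated chain carbon, two bonds along the chain from a sulfonyl sulfur. Going by the values given here, no measured step touches the sulfonyl chain; the only step on record concerns fluorine on an aromatic carbon and gives no guide to this change. With nothing to indicate a move in either direction, the step is expected to stay inside the scatter: for compound 3 the estimated step is a number 2 percentage points lower from compound 2 to compound 3 (within the scatter). Compound 3 is therefore expected to give about 117% in this assay, with a range from 97% to 137%.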

Compound 3, largest response reached (Emax), in percent of the reference or control that the assay uses: 82%
The estimate for compound 3 lay 35 percentage points above the measured number; the measured number lies below the stated range.
By their numbers in this assay, from the lowest: compound 3; then compounds 2 and 1 (each within the scatter of the next).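

In this assay, the sulfonyl chain turns out to be a place where the maximal response can move: 1-hydroxy-1-methylethyl in place of methyl on a saturated chain carbon, two bonds along the chain from a sulfonyl sulfur, gives a number 37 percentage points lower from compound 2 to compound 3 (beyond the scatter) on the shared core. The only earlier step, on an aromatic carbon, stayed within the scatter, so this is the first change among these compounds that separates one compound from another, and it leaves compound 3 with the lowest number of the three. Nothing available on these compounds accounts for the drop.

The single step lengthens the chain, adds the hydroxyl and adds the branching methyl groups all at once, so the compounds shown cannot say which of these goes with the lower response; a plain 3-methylbutyl chain or an unbranched 3-hydroxypropyl chain would separate them. Also open, going by these compounds, are whether an amine or a carboxylic acid in place of the hydroxyl would give a similar number, and whether the same change would give a step of similar size on the core of compound 1.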